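Replacing a phenol with a nitrile on the benzylamine arm

The source may report more compounds than this note shows. Statements on the series, on what has been measured and on what is new or still open speak of the compounds shown alone.

Compound 1, `CN(C)Cc1ccc(CNc2ccc(CCC(=O)O)cc2)cc1`: in a functional assay for agonist activity at Free fatty acid receptor 1 (Homo sapiens) (on this read-out higher numbers stand for an effect only at larger amounts of compound and lower numbers for an effect already at smaller amounts), compound 1 gives < 31700 nM, a limit of the assay.
Compound 2, `O=C(O)CCc1ccc(NCc2ccc(O)cc2)cc1`: in this assay compound 2 gives < 31700 nM, likewise a limit.

Both measured compounds therefore sit at the limit of < 31700 nM in this assay, at which 2 of the 2 values shown sit, and neither supplies a number. For the measured compounds named here, the one measured step, a step that the two limits leave unreadable from compound 1 to compound 2, cannot be read because both ends are limits. Where compound 2 stands is known only to this extent: its value is a limit, and the other value shown is also a limit.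

Compound 3, `N#Cc1ccc(CNc2ccc(CCC(=O)O)cc2)cc1`, is not yet measured. The change from compound 2 to compound 3 is cyano in place of hydroxy on an aromatic carbon. Going by the values given here, no measured step bears on a cyano group, and the only step available is unreadable, so no size or direction of change beyond the scatter can be derived for compound 3.

On these grounds the expectation for compound 3 is simply that it behaves like the measured compounds and again ends at a limit; the estimate for compound 3 in this assay is 20000 nM, between 5000 nM and 31700 nM, meaning an expected step that the limit leaves unreadable from compound 2 to compound 3.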

Compound 3, half-maximal effective concentration: < 31700 nM
Compound 3: a limit, no number; the forecaster's own chance of this, stated with the estimate: 60%; the middle value does not contradict the limit.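

In this assay compound 3 gives < 31700 nM, again a limit and not a number. The steps among compound 1, compound 2 and compound 3 all join limits, and none of them can be read. The compounds shown leave open what number any of them would reach, and whether cyano and hydroxy differ at all in this assay.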